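Replacing Methoxy with a Sulfamoylaminoethylsulfanyl Side Chain

The source may report more compounds than this note shows. Statements on the series, on what has been measured and on what is new or still open speak of the compounds shown alone.

Of the compounds shown here, three have been measured in an assay for inhibition of Indoleamine 2,3-dioxygenase 1 (Homo sapiens), read by fluorescence, with a stated time of 1 h; a higher number here means a weaker inhibitor, a lower number a stronger inhibitor. Compound 1 `NS(=O)(=O)CC(=O)NCCSc1nonc1/C(=N/O)Nc1ccc(F)c(C(F)F)c1` gives 73 nM, compound 2 `CC1(C(=O)NCCSc2nonc2/C(=N/O)Nc2ccc(F)c(C(F)F)c2)CCN1` gives 360 nM, and compound 3 `COc1nonc1/C(=N/O)Nc1ccc(F)c(Br)c1` gives 230 nM. Compound 3 thus stands second highest of the three numbers: its nearest neighbour is compound 2, a gap that lies within the scatter, while compound 1 sits a clear distance lower.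

Compound 4 `NS(=O)(=O)NCCSc1nonc1/C(=N/O)Nc1ccc(F)c(Br)c1` differs from compound 3 in one place: (2-(sulfamoylamino)ethyl)sulfanyl in place of methoxy on an aromatic carbon. Among the compounds with values here, the only single-point step on record, a 4.9-fold higher number from compound 1 to compound 2 (0.69 log units; beyond the scatter), concerns the group on the carbonyl carbon of the side chain and does not itself speak to swapping methoxy for a sulfur-linked chain. What can be said is that compound 1, which carries a sulfur-linked chain ending in a sulfonamide, shows a lower number than compound 3, which carries methoxy; the two also differ on the aryl ring, so this is not a clean comparison.

On that basis compound 4 is expected to move downward in this assay, with a step of a 3.3-fold lower number from compound 3 to compound 4 (0.52 log units; beyond the scatter) estimated from compound 3. The estimate for compound 4 is 70 nM, with a range from 25 nM to 200 nM.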

Compound 4, half-maximal inhibitory concentration: 130 nM
Estimate against measurement, compound 4: 1.9-fold (0.27 log units) below; the measured number falls inside the stated range.
By their numbers in this assay, from the lowest: compounds 1, 4, 3 and 2 (each within the scatter of the next, the first and the last beyond it).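

In this assay, putting (2-(sulfamoylamino)ethyl)sulfanyl in place of methoxy on this aromatic carbon gives a step that stays within the scatter (a 1.8-fold lower number from compound 3 to compound 4 (0.25 log units; within the scatter)), so the two groups cannot be told apart here. Compounds 3 and 4 differ in this one place only, which makes this the first clean reading at this position among the compounds shown, and going from 0 to 2 hydrogen-bond donors, with 1 to 3 hydrogen-bond acceptors, brings no change beyond the scatter. Nothing available explains why the number holds so steady across this exchange.

The compounds shown leave open how much the sulfur link, the length of the chain and its sulfamoylamino end each contribute, since all three enter together in this single exchange. A shorter or longer chain, an oxygen link in place of the sulfur, or an amine or a carboxylic acid at the chain end could separate these contributions at this position.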